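The source may report more compounds than this note shows. Statements on the series, on what has been measured and on what is new or still open speak of the compounds shown alone.

Measured compounds in a functional assay on U-87MG ATCC cells (Homo sapiens) for antiproliferative activity, read by MTT assay, with a stated time of 48 h; a lower number here means a stronger inhibitor, a higher number a weaker inhibitor:
Compound 1 `COc1ccc(-c2nn(-c3ccccc3)cc2C(=O)/C=C\Nc2ccc(F)cc2)cc1` gives 8910 nM.
Compound 2 `COc1ccc(N/C=C\C(=O)c2cn(-c3ccccc3)nc2-c2ccc(OC)cc2)cc1` gives > 50000 nM, a limit of the assay rather than a number.
Compound 3 `COc1ccc(-c2nn(-c3ccccc3)cc2C(=O)/C=C\Nc2cc(OC)c(OC)c(OC)c2)cc1` gives > 50000 nM, likewise a limit.

Compound 2 therefore stands at the limit of > 50000 nM in this assay, at which 2 of the 3 values shown sit, with no measured number of its own. Compound 4 `COc1ccc(N/C=C\C(=O)c2cn(-c3ccccc3)nc2-c2cc(OC)c(OC)c(OC)c2)cc1` is reached by 3,4,5-trimethoxyphenyl in place of 4-methoxyphenyl on an aromatic carbon. Among the measured compounds shown here, no measured step changes a group on that aromatic carbon. For the measured compounds named here, the one swap to 3,4,5-trimethoxyphenyl that is measured sits on the amine nitrogen, an at least 5.6-fold higher number from compound 1 to compound 3 (0.74 log units; beyond the scatter), and the step on the amine-side ring an at least 5.6-fold higher number from compound 1 to compound 2 (0.74 log units; beyond the scatter) also weakened. The step that the two limits leave unreadable from compound 2 to compound 3 is unreadable. With compound 2 already at the limit, compound 4 is expected to stay at or near it, the expected step being an at least 1.1-fold lower number from compound 2 to compound 4 (0.04 log units; that floor lies within the scatter). Compound 4 is estimated at 45000 nM, between 8000 nM and 120000 nM.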

Compound 4, half-maximal inhibitory concentration: 12800 nM
Beside the measured number, compound 4's estimate is 3.5-fold (0.55 log units) above it, and the stated range covers the measured number.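

In this assay, among the compounds shown here, 3,4,5-trimethoxyphenyl in place of 4-methoxyphenyl on this aromatic carbon gives the first readable step at this position: an at least 3.9-fold lower number from compound 2 to compound 4 (0.59 log units; beyond the scatter). On the amine nitrogen, 3,4,5-trimethoxyphenyl replacing a different group, 4-fluorophenyl, gave the opposite direction: an at least 5.6-fold higher number from compound 1 to compound 3 (0.74 log units; beyond the scatter). The step from compound 2 is only a floor, because compound 2 has a limit rather than a number: the limit of > 50000 nM in this assay, at which 2 of the 4 values shown sit.

The compounds shown leave open whether all three methoxy groups are needed at this position, as a dimethoxyphenyl group would show. Also open, on these data alone, is whether a hydroxyl or an amine on this ring would keep the lower number.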